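Swapping the Aryl Ether Arm of Compound 1

The source may report more compounds than this note shows. Statements on the series, on what has been measured and on what is new or still open speak of the compounds shown alone.

Compound 1 `Nc1cc(N)c2nc(-c3ccccc3)c(Oc3ccc(Cl)c(Cl)c3)nc2c1`: 3470 nM
Compound 2 `CCOC(=O)[C@H](CCC(=O)O)NC(=O)c1ccc(CNc2nc3cc(N)cc(N)c3nc2-c2ccccc2)cc1`: 28200 nM
Compound 3 `CCOC(=O)[C@H](CCC(=O)O)NC(=O)c1ccc(Oc2nc3cc(N)cc(N)c3nc2-c2ccccc2)cc1`: a limit, < 100000 nM

In a functional assay on RPMI8266 cells (Homo sapiens) for inhibition, read by sulforhodamine B assay, with a stated time of 48 h (on this read-out higher numbers stand for weaker inhibition of growth and lower numbers for stronger inhibition of growth), compound 1 gives 3470 nM, the lowest of the two numbers shown. Compound 2 gives 28200 nM, a gap beyond the scatter. For compound 3 the assay reports only a limit, < 100000 nM, and no number. Compound 4 `COc1ccc(Sc2nc3cc(N)cc(N)c3nc2-c2ccccc2)cc1` has not yet been measured. It differs from compound 1 in one place: (4-methoxyphenyl)sulfanyl in place of 3,4-dichlorophenoxy on an aromatic carbon. For the measured compounds named here, no measured pair shares this change, so the expectation rests on compound 1 alone. A modest move toward weaker growth inhibition seems plausible, though it may stay within the scatter. The expected step of a 1.7-fold higher number from compound 1 to compound 4 (0.24 log units; within the scatter) is therefore small and uncertain. Compound 4 is estimated at 6000 nM, with a range from 1500 nM to 25000 nM.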

Compound 4, concentration for 50% growth inhibition: 3980 nM
The estimate for compound 4 lay 1.5-fold (0.18 log units) above the measured number, and the stated range covers the measured number.
By their numbers in this assay, from the lowest: compounds 1 and 4 (each within the scatter of the next); then compound 2.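

Replacing 3,4-dichlorophenoxy with (4-methoxyphenyl)sulfanyl on this aromatic carbon gives a 1.1-fold higher number from compound 1 to compound 4 (0.06 log units; within the scatter) in this assay. At this position, then, an aryl arm joined through sulfur and carrying methoxy matches, within the scatter, one joined through oxygen and carrying two chlorines. Nothing measured here explains this match.

On these data alone, the linking atom and the ring substituents changed together, so their separate contributions remain unknown. As far as these compounds go, it also remains open how a piperidine at this position would perform.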